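The source may hold more compounds than are shown below. What is called first, only, known or untested is meant among the compounds shown, and "the series" means these compounds.

Of the compounds shown here, three built on one shared core have been tested in a functional assay on the whole organism with Rattus norvegicus as the target; on this read-out lower numbers stand for an effect already at smaller amounts and higher numbers for an effect only at larger amounts of compound. Compound 1 `CCCn1c(=N)sc2cc(OC(F)(F)F)ccc21` gives 4.5 mg/kg in this assay. Compound 2 `N=c1sc2cc(OC(F)(F)F)ccc2n1CCO` gives 8 mg/kg. Compound 3 `CSCCn1c(=N)sc2cc(OC(F)(F)F)ccc21` gives 1 mg/kg, the lowest of the three numbers, reached through a 4.5-fold lower number from compound 1 to compound 3 (0.65 log units; beyond the scatter) and an 8.0-fold lower number from compound 2 to compound 3 (0.90 log units; beyond the scatter); the remaining step, a 1.8-fold higher number from compound 1 to compound 2 (0.25 log units; within the scatter), stayed within the scatter. Compound 4 `CS(=O)(=O)CCCn1c(=N)sc2cc(OC(F)(F)F)ccc21` carries (methylsulfonyl)methyl in place of methylsulfanyl on a saturated chain carbon, two bonds along the chain from an aromatic nitrogen. Among the measured compounds shown here, no measured step introduces a methylsulfonyl group, so the direction of this change rests on indirect evidence. Because the methylsulfanyl group that gave the gain in a 4.5-fold lower number from compound 1 to compound 3 (0.65 log units; beyond the scatter) is itself removed, a modest rise is expected, namely a 2.5-fold higher number from compound 3 to compound 4 (0.40 log units; beyond the scatter). Compound 4 is therefore estimated at 2.5 mg/kg, with a range from 0.8 mg/kg to 8 mg/kg.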

Compound 4, dose for half-maximal effect: 5 mg/kg
Compound 4: middle estimate off by 2.0-fold (0.30 log units), on the low side; the range from low to high includes it.
By their numbers in this assay, from the lowest: compound 3; then compounds 1, 4 and 2 (each within the scatter of the next).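

In this assay the advantage of the 2-(methylsulfanyl)ethyl chain does not carry over to the 3-(methylsulfonyl)propyl chain, as shown by a 5.0-fold higher number from compound 3 to compound 4 (0.70 log units; beyond the scatter) here. The new chain gives no separation from the other two chains, with a 1.1-fold higher number from compound 1 to compound 4 (0.05 log units; within the scatter) and a 1.6-fold lower number from compound 2 to compound 4 (0.20 log units; within the scatter) as the remaining steps. No measurement here explains this result.

From the compounds shown here alone, the change adds both oxygens and a chain carbon, so their separate contributions remain open. Also open, going by these compounds, is how a 2-(methylsulfonyl)ethyl chain, an amine or a carboxylic acid would behave in this place.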